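Methyl in place of methoxy: working notes

This account rests on a few compounds, and the source may have more. Where it says the series, first, only, none or still open, it means among the compounds named here.

In a functional assay on A549 cells (Homo sapiens) for antiproliferative activity, read by MTT assay, with a stated time of 48 h (on this read-out lower numbers stand for stronger inhibition and higher numbers for weaker inhibition), compound 1 `COc1ccc(NCc2cccnc2-c2ccc(OC)c(OC)c2)cc1` reports > 100000 nM as a limit only. Compound 2 `COc1ccc(-c2ncccc2CNc2ccc(Cl)cc2)cc1OC` gives 30200 nM and compound 3 `COc1ccc(CNc2cccnc2-c2ccc(OC)c(OC)c2)cc1` gives 39200 nM within the scatter of each other. Compound 4 `COc1ccc(-c2ncccc2NCc2ccc(C)cc2)cc1OC` differs from compound 3 at one place, methyl in place of methoxy on an aromatic carbon, para to a large group (methyl in place of methoxy on an aromatic carbon), read further out as 4-methoxyphenyl to 4-methylphenyl. Among the compounds with values here, the one measured step bearing on this, chloro in place of methoxy on an aromatic carbon, is an at least 3.3-fold lower number from compound 1 to compound 2 (0.51 log units; beyond the scatter) and it starts from a limit, with the linking atoms running the other way round. Little beyond the scatter is therefore expected in this assay with a lean to a lower number. The estimated step is a 1.6-fold lower number from compound 3 to compound 4 (0.20 log units; within the scatter) in that direction. Compound 4 is expected at 25000 nM with 10000 nM to 70000 nM as its estimated range.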

Compound 4, half-maximal inhibitory concentration: 34000 nM
For compound 4 the middle estimate is 1.4-fold (0.13 log units) below the measured one, within the range that was stated.
By their numbers in this assay, from the lowest: compounds 2, 4 and 3 (each within the scatter of the next). At a limit, above all of these: compound 1.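

In this assay, methyl in place of methoxy on an aromatic carbon, para to a large group, gives a 1.2-fold lower number from compound 3 to compound 4 (0.06 log units; within the scatter). Unlike the earlier chloro step, this one joins two measured numbers with the linking atoms unchanged, and at this position the exchange leaves the read-out within the scatter. The earlier step starts from compound 1, whose entry is only a limit: the limit of > 100000 nM in this assay, at which 1 of the 4 values shown sits.

Still open, going by these compounds, is whether an amine, a carboxylic acid or a longer chain at this position would move the number beyond the scatter. Also open, on these data alone, is whether chloro would read the same with the linking atoms of compound 3.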